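A few compounds are considered here, and "the series" means these few. Any claim that something is new, unique, unknown or untested is made for them only; others in the source may bear on it.

Compound 1 `COc1ccc(OC(=O)Nc2ccc([Se]C#N)cc2)cc1` gives 41500 nM.
Compound 2 `C=CCOC(=O)Nc1ccc([Se]C#N)cc1` gives 48600 nM.
Compound 3 `O=C(Nc1ccc([Se][Se]c2ccc(NC(=O)Oc3ccc(F)cc3)cc2)cc1)Oc1ccc(F)cc1` gives 51900 nM.

In a functional assay on HT-29 cells (Homo sapiens) for cytotoxicity, read by MTT assay, with a stated time of 72 h (on this read-out lower numbers stand for stronger inhibition of growth and higher numbers for weaker inhibition of growth), compound 2 stands second highest of the three numbers; compound 3 is nearest to it and compound 1 furthest, and both gaps lie within the scatter, so the three measured compounds cannot be put in any order. Compound 4 `N#C[Se]c1ccc(NC(=O)Oc2ccccc2)cc1` differs from compound 2 by phenyl in place of allyl on an oxygen next to a carbonyl group. Among the measured compounds shown here, no step between measured compounds that differ in one place is available, so there is nothing to lean on beyond the closeness of the three values. The three measured compounds, with quite different groups on that oxygen, all sit together, so the step from compound 2 to compound 4 is expected to be small, with no direction beyond the scatter. On that reasoning compound 4 is expected to give about 45000 nM, between 20000 nM and 100000 nM, a step of a 1.1-fold lower number from compound 2 to compound 4 (0.03 log units; within the scatter) that is expected to stay inside the scatter.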

Compound 4, concentration for total growth inhibition: 41700 nM
Compound 4: middle estimate off by 1.1-fold (0.03 log units), on the high side; low and high end bracket the measured number.
By their numbers in this assay, from the lowest: compounds 1, 4, 2 and 3 (each within the scatter of the next).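

In this assay, among the compounds shown here, phenyl in place of allyl on an oxygen next to a carbonyl group gives a 1.2-fold lower number from compound 2 to compound 4 (0.07 log units; within the scatter) and is the first one-place reading at this oxygen, showing that these two groups can be exchanged there without a change beyond the scatter. Hydrogen in place of methoxy on an aromatic carbon gives a 1.0-fold higher number from compound 1 to compound 4 (0.00 log units; within the scatter) and likewise leaves the number inside the scatter. No supporting evidence bears on either result.

Going by these compounds, whether an amine, a carboxylic acid or a longer chain on that oxygen would move the number out of this narrow range stays open.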